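Swapping a Bromophenyl for a Dimethylphenyl Ether

The source may hold more compounds than are shown below. What is called first, only, known or untested is meant among the compounds shown, and "the series" means these compounds.

Three measured compounds share one core and differ only in the aryl group on an oxygen on a saturated carbon. In a functional assay on A549 cells (Homo sapiens) for antiproliferative activity, read by MTT assay, with a stated time of 72 h (a lower number here means a stronger inhibitor, a higher number a weaker inhibitor), compound 1 `NC1=NC2(CCOCC2)N(OCCCOc2cc(Cl)c(Cl)cc2Cl)C(N)=N1` gives 680 nM, compound 2 `Cc1ccc(OCCCON2C(N)=NC(N)=NC23CCOCC3)cc1` gives 1060 nM, and compound 3 `NC1=NC2(CCOCC2)N(OCCCOc2ccc(Br)cc2)C(N)=N1` gives 280 nM, the lowest of the three: the step of a 2.4-fold lower number from compound 1 to compound 3 (0.39 log units; beyond the scatter) and the step of a 3.8-fold lower number from compound 2 to compound 3 (0.58 log units; beyond the scatter) both lie beyond the scatter, whereas a 1.6-fold higher number from compound 1 to compound 2 (0.19 log units; within the scatter). Compound 4 `Cc1cc(C)cc(OCCCON2C(N)=NC(N)=NC23CCOCC3)c1` differs from compound 3 by 3,5-dimethylphenyl in place of 4-bromophenyl on an oxygen on a saturated carbon. The step of a 3.8-fold lower number from compound 2 to compound 3 (0.58 log units; beyond the scatter) bears most directly on this change, and compound 4 reverses its direction, so a higher number is expected for compound 4, with a 3.0-fold higher number from compound 3 to compound 4 (0.48 log units; beyond the scatter). Compound 4 is therefore estimated at 850 nM, within a range from 350 nM to 2000 nM.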

Compound 4, half-maximal inhibitory concentration: 710 nM
Estimate against measurement, compound 4: 1.2-fold (0.08 log units) above; measured number inside the range.
By their numbers in this assay, from the lowest: compound 3; then compounds 1, 4 and 2 (each within the scatter of the next).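

In this assay compound 3 now stands apart from all three other compounds, since 3,5-dimethylphenyl does not match 4-bromophenyl at this position (a 2.5-fold higher number from compound 3 to compound 4 (0.40 log units; beyond the scatter)). Compound 4 cannot be separated from the compounds with a single methyl or three chloro groups on the ring (a 1.5-fold lower number from compound 2 to compound 4 (0.17 log units; within the scatter); a 1.0-fold higher number from compound 1 to compound 4 (0.02 log units; within the scatter)), so neither group count nor group type sorts these three. No measurement here explains why the 4-bromophenyl group stands out.

From the compounds shown here alone, whether 4-chlorophenyl or 4-iodophenyl would match compound 3 remains open. So does the effect of an amine on the ring.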